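This account rests on a few compounds, and the source may have more. Where it says the series, first, only, none or still open, it means among the compounds named here.

Measured so far:
Compound 1, `Cc1cc(C)cc(NC(=O)COc2cc(C)nc3ccccc23)c1`: > 100000 nM
Compound 2, `COc1ccc2nc(C)cc(OCC(=O)NCc3cc(C)cc(C)c3)c2c1`: > 100000 nM

In a toxicity assay on HepG2 cells (Homo sapiens) for inhibition, read by CellTiter-Glo, with a stated time of 48 h (a lower number here means a stronger inhibitor, a higher number a weaker inhibitor), compound 1 gives > 100000 nM, which is a limit of the assay and not a number. Compound 2 gives > 100000 nM in this assay, likewise a limit and not a number. Going by the values given here, compound 2 therefore stands where every value so far stands: at the edge of what the assay can report, and the only evidence about this assay is the limit of > 100000 nM in this assay, at which 2 of the 2 values shown sit. Because both values are limits, no step between measured compounds can be counted, and nothing has yet shown a compound of this series acting as an inhibitor in this assay.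

Compound 3, `COc1ccc2nc(C)cc(OCC(=O)Nc3ccccn3)c2c1`, differs from compound 2 at a single place: pyridin-2-yl in place of 3,5-dimethylbenzyl on an amide-type nitrogen. The group that leaves is larger than the one that enters, and the ring that enters carries a nitrogen.

Given that each compound so far sits at the limit, the step from compound 2 to compound 3 is expected to be none beyond the usual scatter, namely a number no higher from compound 2 to compound 3 (the limit leaves the size open), due to the limit of > 100000 nM in this assay, at which 2 of the 2 values shown sit. Compound 3 is accordingly expected to give about 100000 nM, with a range from 30000 nM to 300000 nM, most probably again reported only as a limit.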

Compound 3, half-maximal inhibitory concentration: > 100000 nM
Compound 3: no number, only a limit; the forecaster's own chance of this, stated with the estimate: 80%; the middle value sits exactly at the limit.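

No step can be read between compound 2 and compound 3, as each value is only a limit of the assay and not a number: the limit of > 100000 nM in this assay, at which 3 of the 3 values shown sit. The compounds shown leave open whether any compound of this series reaches a measurable value in this assay, and what size of step the exchange of 3,5-dimethylbenzyl for pyridin-2-yl truly makes.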